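Methoxy in place of trifluoromethyl on the benzyl arm

The source may report more compounds than this note shows. Statements on the series, on what has been measured and on what is new or still open speak of the compounds shown alone.

Among the compounds with values here, compound 1 `O=C(CCC1=CCN(Cc2ccc(C(F)(F)F)cc2)C1=O)NO` is the only member of the set with a number in a functional assay on ACHN cells (Homo sapiens) for antiproliferative activity (a lower number here means a stronger inhibitor of growth, a higher number a weaker inhibitor of growth), where compound 1 gives 4290 nM. Compound 2 `COc1ccccc1CN1CC=C(CCC(=O)NO)C1=O` reaches only a limit of the assay: in this assay compound 2 gives > 10000 nM (the limit of > 10000 nM in this assay, at which 1 of the 2 values shown sits). Compound 3 `COc1ccc(CN2CC=C(CCC(=O)NO)C2=O)cc1` differs from compound 1 by methoxy in place of trifluoromethyl on an aromatic carbon. Within the data shown here, no measured step covers this change. The expected step is a loss beyond the scatter, a 2.1-fold higher number from compound 1 to compound 3 (0.32 log units; beyond the scatter). Compound 2, also carrying a methoxy, gives > 10000 nM, a limit. For compound 3 in this assay the estimate is 9000 nM, expected between 3000 nM and 25000 nM.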

Compound 3, concentration for 50% growth inhibition: 2480 nM
Compound 3: the middle estimate sits 3.6-fold (0.56 log units) above what was measured; measured number outside the range, below it.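

In this assay, methoxy at this place, para to a large group, gives a 1.7-fold lower number from compound 1 to compound 3 (0.24 log units; within the scatter), so trifluoromethyl and methoxy cannot be told apart here. The presence of a methoxy alone therefore does not push a compound of this series out of the measurable range. Compound 2, which also carries a methoxy, stands at a limit of the assay and not at a number: the limit of > 10000 nM in this assay, at which 1 of the 3 values shown sits.

Going by these compounds, whether an amine or a carboxylic acid at this place would stay level with these two groups remains open. On these data alone, what the placing of the methoxy contributes also remains open, as compound 2 offers only a limit.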